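Urea-to-benzamide swap on the pyrazole series

The compounds below may be only part of what the source reports. "The series", "measured", "known", "first", "only" and "open" are said of these compounds alone.

Measured so far:
compound 1 `COc1cc(-c2nn(-c3cccc(NC(=O)Nc4ccc(Cl)c(Cl)c4)c3)cc2-c2ccncc2)ccc1Cl` — 1100 nM
compound 2 `O=C(Nc1cccc(-n2cc(-c3ccncc3)c(-c3ccc(Cl)c(O)c3)n2)c1)Nc1ccc(Cl)c(Cl)c1` — 1380 nM
compound 3 `O=C(Nc1cccc(-n2cc(-c3ccncc3)c(-c3ccc(Cl)c(O)c3)n2)c1)Nc1cc(C(F)(F)F)cc(C(F)(F)F)c1` — 1150 nM

In a functional assay on MOLT-4 cells (Homo sapiens) for inhibition, read by sulforhodamine B assay, with a stated time of 48 h (on this read-out lower numbers stand for stronger inhibition of growth and higher numbers for weaker inhibition of growth), compound 1 gives 1100 nM. Compound 2 gives 1380 nM and compound 3 gives 1150 nM; the three numbers sit close together, and the distance from compound 1 to either of the other two is within the scatter. Among the compounds with values here, the one single-point step measured here, a 1.3-fold higher number from compound 1 to compound 2 (0.10 log units; within the scatter), shows that the methyl-to-hydrogen change on the ring oxygen leaves this assay essentially unmoved. Compound 2 and compound 3 differ in the aryl group on the far side of the urea and give numbers that are close to each other as well.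

Compound 4 `COc1cc(-c2nn(-c3cccc(NC(=O)c4ccccc4)c3)cc2-c2ccncc2)ccc1Cl` is compound 1 with phenyl in place of (3,4-dichlorophenyl)amino on a carbonyl carbon. Within the data shown here, no measured step bears directly on this change: the steps seen so far touch the ring oxygen substituent and the distal urea aryl group, while this one removes the urea nitrogen and its aryl group altogether and replaces them with a benzoyl unit. The series so far has not shown that this part of the molecule is indifferent, so a weakening beyond the scatter is the more cautious expectation.

Compound 4 is therefore expected to give about 3500 nM in this assay, with a range of 900 nM to 14000 nM, which corresponds to an expected step of a 3.2-fold higher number from compound 1 to compound 4 (0.50 log units; beyond the scatter).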

Compound 4, concentration for 50% growth inhibition: 701 nM
Compound 4: the middle estimate sits 5.0-fold (0.70 log units) above what was measured, outside the stated range (below it).
By their numbers in this assay, from the lowest: compounds 4, 1, 3 and 2 (each within the scatter of the next).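

In this assay the change from (3,4-dichlorophenyl)amino to phenyl on a carbonyl carbon gives a 1.6-fold lower number from compound 1 to compound 4 (0.20 log units; within the scatter) and thus leaves the two numbers indistinguishable. The earlier steps shown here touched only the substituent on the ring oxygen and the aryl group on the far side of the urea, whereas this pair shows that, on the core of compound 1, the urea can give way to a benzamido group with no readable loss, even with the amino nitrogen and both chlorine atoms gone. For this pair, then, neither that nitrogen nor the dichloro pattern is needed to hold a number of this size in this growth read-out, although one pair sets no rule for the series.

Still open, going by these compounds, is whether the benzamido series carries substituents on its phenyl ring, such as a dimethylamino group, a carboxylic acid or the chlorine atoms lost here, and whether a longer chain between the carbonyl and the phenyl ring is accepted. Also open, on these data alone, is whether hydrogen in place of methyl on the ring oxygen reads the same in the benzamido series as in the urea pair, and no accompanying measurement offers an explanation for the result.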